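Bromo to Methyl Where Every Value Is a Limit

The compounds below may be only part of what the source reports. "The series", "measured", "known", "first", "only" and "open" are said of these compounds alone.

Measured compounds:
compound 1, `O=C1Nc2ccc(Br)cc2/C1=N/NC(=S)N/N=C/c1ccc(-c2ccccc2)cc1`: > 50000 nM
compound 2, `O=C1Nc2ccc(Br)cc2/C1=N/NC(=S)N/N=C/c1ccccc1Br`: > 50000 nM
compound 3, `Cc1ccc2c(c1)/C(=N/NC(=S)N/N=C/c1ccccc1Br)C(=O)N2`: > 50000 nM

In a functional assay on COS-7 cells (Chlorocebus aethiops) for inhibition, read by MTT assay (a higher number here means a weaker inhibitor, a lower number a stronger inhibitor), compound 1 gives no number, only a limit of the assay, > 50000 nM. Compound 2 likewise returns a limit, > 50000 nM. Compound 3 also returns a limit, > 50000 nM. Compound 3 differs from compound 2 by methyl in place of bromo on an aromatic carbon, and the step that the two limits leave unreadable from compound 2 to compound 3 cannot be read, because all three values sit at the limit of > 50000 nM in this assay, at which 3 of the 3 values shown sit. Compound 1 and compound 2 differ in more than one place, and the difference between the two cores is not broken down here.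

Compound 4, `Cc1ccc2c(c1)/C(=N/NC(=S)N/N=C/c1ccc(-c3ccccc3)cc1)C(=O)N2`, differs from compound 1 by methyl in place of bromo on an aromatic carbon, the same change made from compound 2 to compound 3. The step from compound 1 to compound 4 is expected to be a step that the limit leaves unreadable from compound 1 to compound 4, an expectation that rests on the unreadable step that the two limits leave unreadable from compound 2 to compound 3 and on compound 1 sitting at the limit > 50000 nM. Compound 4 is therefore estimated at around 60000 nM, and most likely the assay will again report only a limit.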

Compound 4, half-maximal inhibitory concentration: > 50000 nM
Compound 4 was reported as a limit; the forecaster's own chance of this, stated with the estimate: 85%; the middle value is on the limit's open side.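

In this assay compound 4 gives only a limit, > 50000 nM. No step can be read between compound 1 and compound 4, or between any other pair, because every value is a limit: the limit of > 50000 nM in this assay, at which 4 of the 4 values shown sit. The compounds shown leave open how strongly any of the four inhibits in this assay, and whether methyl in place of bromo changes that at all.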